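Benzoxazole sulfonamides at the assay limit; nitro variant

This account rests on a few compounds, and the source may have more. Where it says the series, first, only, none or still open, it means among the compounds named here.

Compound 1 `O=S(=O)(Nc1ccc2oc(-c3ccccc3)nc2c1)c1ccc(Cl)cc1` gives > 100000 nM in an assay on cells for inhibition of HSP60/HSP10 (Homo sapiens), with a stated time of 60 min (a higher number here means a weaker inhibitor, a lower number a stronger inhibitor), a limit of the assay and not a number.
Compound 2 `O=S(=O)(Nc1ccc2oc(-c3ccccc3)nc2c1)c1ccc(Cl)c(C(F)(F)F)c1` gives > 100000 nM in this assay, again a limit.
Compound 3 `O=S(=O)(Nc1ccc2oc(-c3ccccc3)nc2c1)c1ccc(Cl)c(Cl)c1` gives > 100000 nM in this assay, also a limit.

All three values sit at the limit of > 100000 nM in this assay, at which 3 of the 3 values shown sit, so compound 3 stands nowhere readable: it is known only as a limit, as are the two others. The steps a step that the two limits leave unreadable from compound 1 to compound 2, a step that the two limits leave unreadable from compound 1 to compound 3 and a step that the two limits leave unreadable from compound 2 to compound 3 are therefore without readable size in either direction.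

Compound 4 `O=[N+]([O-])c1cc(S(=O)(=O)Nc2ccc3oc(-c4ccccc4)nc3c2)ccc1Cl` differs from compound 3 by nitro in place of chloro on an aromatic carbon. The measured steps that bear on this change are those among compounds 1, 2 and 3, and none of them yields a size, so they give no direction to expect in this assay and no step beyond the scatter can be read from them.

Compound 4 is therefore expected to remain at or near the limit, with an estimated step that the limit leaves unreadable from compound 3 to compound 4 that is itself uncertain. The estimate for compound 4 in this assay is 150000 nM, with a range from 30000 nM to 1000000 nM.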

Compound 4, half-maximal inhibitory concentration: 17000 nM
For compound 4 the middle estimate is 8.8-fold (0.95 log units) above the measured one, outside the stated range (below it).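

Compound 4 is the only one of the four to give a measured number in this assay, so a change at this position, ortho to a chloro group, can bring the series off the limit. Nitro in place of chloro gives an at least 5.8-fold lower number from compound 3 to compound 4 (0.76 log units; beyond the scatter), nitro in place of trifluoromethyl gives an at least 5.8-fold lower number from compound 2 to compound 4 (0.76 log units; beyond the scatter), and nitro in place of hydrogen gives an at least 5.8-fold lower number from compound 1 to compound 4 (0.76 log units; beyond the scatter); the steps among the other three compounds cannot be read. Compound 1, compound 2 and compound 3 each stay at a limit of the assay, and of the four groups at this position only nitro gives a number: the limit of > 100000 nM in this assay, at which 3 of the 4 values shown sit.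

From the compounds shown here alone, the true size of each of the three steps stays open, as only a bound is known for each. Going by these compounds, how a nitrile, an amine or a carboxylic acid would read at this position also stays open.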